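Swapping a tert-butyl for trifluoroethyl on a weak inhibitor

The compounds below may be only part of what the source reports. "The series", "measured", "known", "first", "only" and "open" are said of these compounds alone.

Measured so far:
- compound 1, `OCc1ccc(-c2nn(Cc3ccccc3F)c3ccncc23)o1`, 9800 nM
- compound 2, `Cc1coc(-c2nn(Cc3ccccc3F)c3ncccc23)n1`, 1200 nM
- compound 3, `CC(C)(C)c1cnc(-c2nn(Cc3ccccc3F)c3ncccc23)nc1N`, 709000 nM

All three compounds were tested in a functional assay (aorta) with Oryctolagus cuniculus as the target; on this read-out higher numbers stand for weaker inhibition and lower numbers for stronger inhibition. Among them compound 3 stands at the highest number, beyond the scatter from both others: compound 1 sits far lower at 9800 nM, and compound 2 lower still at 1200 nM. Compound 3 is therefore the weakest inhibitor of the three shown.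

The next compound, compound 4, `Nc1nc(-c2nn(Cc3ccccc3F)c3ncccc23)ncc1CC(F)(F)F`, differs from compound 3 in one place: 2,2,2-trifluoroethyl in place of tert-butyl on an aromatic carbon. Among the compounds with values here, no measured pair in this set shows such a change, so there is nothing here to say how large its effect usually is. The expectation for the step from compound 3 to compound 4 is therefore cautious: a change of a 1.8-fold lower number from compound 3 to compound 4 (0.25 log units; within the scatter) in this assay, which is expected to stay within or only slightly beyond the scatter, with no firm direction. Compound 4 is estimated at 400000 nM in this assay, within a range from 60000 nM to 2500000 nM.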

Compound 4, half-maximal inhibitory concentration: 508000 nM
The estimate for compound 4 lay 1.3-fold (0.10 log units) below the measured number, within the range that was stated.
By their numbers in this assay, from the lowest: compound 2; then compound 1; then compounds 4 and 3 (each within the scatter of the next).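

For the aromatic carbon ortho to an amino group, putting 2,2,2-trifluoroethyl in place of tert-butyl in this assay gives a 1.4-fold lower number from compound 3 to compound 4 (0.14 log units; within the scatter) and so the two groups cannot be told apart on this read-out. Within the data shown here, this is the first pair in the set that differs in one place, and it shows that this exchange, from four carbons to two carbons and three fluorines, does not move the number beyond the usual scatter. Nothing measured here offers an explanation for this outcome.

On these data alone, it remains open whether any group at this position can shift the number beyond the scatter, for example a methyl, a primary amine or a carboxylic acid. A single pair also cannot show whether the same exchange would behave alike on another core.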